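Dropping the Phenolic Hydroxy from Compound 1

This account rests on a few compounds, and the source may have more. Where it says the series, first, only, none or still open, it means among the compounds named here.

In a functional assay on PC-3 cells (Homo sapiens) for antiproliferative activity, read by MTT assay, with a stated time of 48 h (on this read-out lower numbers stand for stronger inhibition and higher numbers for weaker inhibition), the three measured compounds stand as follows:
compound 1, `COc1cc(O)ccc1N1CCN(CC(O)COc2ccc(O)c3ccccc23)CC1`: 45700 nM
compound 2, `Oc1ccccc1N1CCN(CC(O)COc2cccc3ccccc23)CC1`: 21700 nM
compound 3, `Oc1ccc(N2CCN(CC(O)COc3cccc4ccccc34)CC2)c(O)c1`: 30300 nM

Compound 1 gives the highest of the three numbers in this assay; its gap to compound 3 lies within the scatter, while its gap to compound 2 lies beyond it. Compound 4, `COc1ccccc1N1CCN(CC(O)COc2ccc(O)c3ccccc23)CC1`, differs from compound 1 by hydrogen in place of hydroxy on an aromatic carbon. Among the measured compounds shown here, only one measured step bears on this change, and it runs the opposite way: a 1.4-fold higher number from compound 2 to compound 3 (0.14 log units; within the scatter). Reversed, hydrogen in place of hydroxy might bring a slightly lower number, though a single step of that size supports nothing beyond the scatter. Compound 4 is therefore expected to give 35000 nM in this assay, within 15000 nM to 80000 nM. The step expected is a 1.3-fold lower number from compound 1 to compound 4 (0.12 log units; within the scatter).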

Compound 4, half-maximal inhibitory concentration: 28000 nM
The estimate for compound 4 lay 1.3-fold (0.10 log units) above the measured number; low and high end bracket the measured number.
By their numbers in this assay, from the lowest: compounds 2, 4, 3 and 1 (each within the scatter of the next, the first and the last beyond it).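

Hydrogen in place of hydroxy, read as 4-hydroxy-2-methoxyphenyl to 2-methoxyphenyl, now has a direct reading in this assay: it gives a 1.6-fold lower number from compound 1 to compound 4 (0.21 log units; within the scatter) on this second core. Neither this step nor the earlier one leaves the scatter, so the hydroxy at this place shows no clear effect on the number on either core. The two readings also agree with each other: the same change on two cores in this assay, a 1.4-fold higher number (0.14 log units; within the scatter) from compound 2 to compound 3 and a 1.6-fold higher number (0.21 log units; within the scatter) from compound 4 to compound 1, 1.2-fold (0.07 log units) apart, within the scatter of two such steps.

Still open, as far as these compounds go, is whether an amine or a carboxylic acid at this same place, para to the large group, would move the number beyond the scatter.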